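The source may hold more compounds than are shown below. What is called first, only, known or untested is meant among the compounds shown, and "the series" means these compounds.

Measured so far in a functional assay (trachea) with Rattus norvegicus as the target; a lower number here means a less potent compound, a higher number a more potent compound, by a factor of ten per unit of this negative logarithm:
compound 1 `CC1(C)C=C(n2ccccc2=O)c2ccccc2O1`: 5.05
compound 2 `COc1ccc2c(c1)C(n1ccccc1=O)=CC(C)(C)O2`: 5.99
compound 3 `CC1(C)C=C(n2ccccc2=O)c2cc(C(=O)c3ccccc3)ccc2O1`: 6.21

Compound 3 holds the highest number of the three. Its step from compound 2 is a number 0.22 log units higher from compound 2 to compound 3 (within the scatter), which sets no order between the two, while the step from compound 1 to compound 3 is a number 1.16 log units higher from compound 1 to compound 3 (beyond the scatter). The change from compound 1 to compound 2 is methoxy in place of hydrogen on an aromatic carbon and it made a step of a number 0.94 log units higher from compound 1 to compound 2 (beyond the scatter) in this assay.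

Compound 4 `COc1ccc(C(=O)c2ccc3c(c2)C(n2ccccc2=O)=CC(C)(C)O3)cc1` is not yet measured. It differs from compound 3 by methoxy in place of hydrogen on an aromatic carbon. The cores of compound 1 and compound 3 differ by benzoyl in place of hydrogen on an aromatic carbon. The place differs: in compound 2 the methoxy sits on a ring that is part of a fused or bridged system of two rings, meta to a fused ring and para to a fused ring; in compound 4 it sits para to a large group, the difference cut one bond further out reading phenyl to 4-methoxyphenyl. It is thus the same kind of change, not the same.

The expected step from compound 3 to compound 4 in this assay is a number 0.29 log units higher from compound 3 to compound 4 (within the scatter), smaller than the earlier step because the step of a number 0.94 log units higher from compound 1 to compound 2 (beyond the scatter) was made at a different place, on the core of compound 1. Among the compounds with values here, only that one instance is available. For compound 4 the estimate in this assay is 6.5, ranging from 5.9 to 7.1.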

Compound 4, logarithm of the reciprocal of the active concentration, log(1/C): 5.72
Beside the measured number, compound 4's estimate is 0.78 log units above it; the measured number lies below the stated range.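

In this assay, methoxy in place of hydrogen gives a number 0.49 log units lower from compound 3 to compound 4 (beyond the scatter), so the rise seen on the core of compound 1 does not carry over to this instance. The two instances of the change disagree in direction: the same change on two cores in this assay, a number 0.94 log units higher (beyond the scatter) from compound 1 to compound 2 and a number 0.49 log units lower (beyond the scatter) from compound 3 to compound 4, 1.43 log units apart, beyond the scatter of two such steps

This does not show whether the core or the place decides the step: in compound 4 the methoxy sits para to a large group, the change reading phenyl to 4-methoxyphenyl, while in compound 2 it stands on the core itself, and a single pair of each kind cannot separate the two.

Going by these compounds, whether the lower number of compound 4 belongs to methoxy alone or to any group at that place stays open, and a hydroxyl, an amine or a carboxylic acid there would bear on this. Also open, on these data alone, is how a methoxy elsewhere on the phenyl ring of the benzoyl group would read.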